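This account rests on a few compounds, and the source may have more. Where it says the series, first, only, none or still open, it means among the compounds named here.

Measured so far:
compound 1, `COc1ccc(CCCCCCCCOc2ccc(CSc3cccc(C(=O)O)c3)nc2/C=C/C(=O)O)cc1`, which in a functional assay on the whole organism with Homo sapiens as the target, read by calcium flux (a lower number here means a stronger inhibitor, a higher number a weaker inhibitor), gives 550 nM;
compound 2, `COc1ccc(CCCCCCCCOc2ccc(C[S+]([O-])Cc3cccc(C(=O)O)c3)nc2/C=C/C(=O)O)cc1`, which in this assay gives 3300 nM.

Compound 2 holds the highest of the two numbers; its nearest neighbour is compound 1, and the only step shown is a 6.0-fold higher number from compound 1 to compound 2 (0.78 log units; beyond the scatter). Compound 3, `COc1ccc(CCCCCCCCOc2ccc(CSCc3ccccc3C(=O)O)nc2/C=C/C(=O)O)cc1`, has not yet been measured. It differs from compound 2 in one place: a group of 11 heavy atoms (8 carbon, 2 oxygen, 1 sulfur; one six-membered aromatic ring of carbon only) in place of a group of 12 heavy atoms (8 carbon, 3 oxygen, 1 sulfur; one six-membered aromatic ring of carbon only), on a saturated chain carbon bound to an aromatic carbon. The step from compound 1 to compound 2 bears on this change, since both concern the group on the saturated chain carbon bound to an aromatic carbon, and that step was modest but beyond the scatter. Compound 3, however, carries the (2-carboxybenzyl)sulfanyl group rather than the group of compound 1, so a full return is not assured. Compound 3 is therefore expected to show a step of a 3.7-fold lower number from compound 2 to compound 3 (0.56 log units; beyond the scatter) in this assay. The estimated value for compound 3 is 900 nM, within 250 nM to 3000 nM.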

Compound 3, half-maximal inhibitory concentration: 710 nM
Estimate against measurement, compound 3: 1.3-fold (0.10 log units) above; the measured number falls inside the stated range.
By their numbers in this assay, from the lowest: compounds 1 and 3 (each within the scatter of the next); then compound 2.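

In this assay, within the data shown here, the (2-carboxybenzyl)sulfanyl group on the saturated chain carbon bound to an aromatic carbon gives a 4.6-fold lower number from compound 2 to compound 3 (0.67 log units; beyond the scatter), so a benzyl group on the sulfur is compatible with a number well clear of the one compound 2 holds. Exchanging 3-carboxyphenyl for 2-carboxybenzyl on the sulfur gives a 1.3-fold higher number from compound 1 to compound 3 (0.11 log units; within the scatter), which is within the scatter, so this assay does not separate these two groups. No measurement shown here explains either step.

Compound 3 differs from compound 2 in both the oxygen count of the group and the place of its carboxylic acid, so the compounds shown do not tell which of the two goes with the step. As far as these compounds go, the (3-carboxybenzyl)sulfanyl group would divide them, and how a tetrazole in place of the carboxylic acid would read also remains open.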